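Notes on the substituent at the ring amide nitrogen

This account rests on a few compounds, and the source may have more. Where it says the series, first, only, none or still open, it means among the compounds named here.

Compound 1 `COc1ncc(-c2ccc3c(c2)N(CCC(=O)N2CCOCC2)C(=O)CO3)cc1NS(=O)(=O)c1ccc(F)cc1F` and compound 2 `COc1ncc(-c2ccc3c(c2)N(Cc2ccncc2)C(=O)CO3)cc1NS(=O)(=O)c1ccc(F)cc1F` share one core and differ only on the saturated chain carbon bound to an amide-type nitrogen in a ring. In a functional assay on MDA-MB-231 cells (Homo sapiens) for antiproliferative activity, read by sulforhodamine B assay, with a stated time of 72 h (on this read-out lower numbers stand for stronger inhibition and higher numbers for weaker inhibition), compound 1 gives 3260 nM and compound 2 gives 5490 nM, the higher of the two numbers, though the step of a 1.7-fold higher number from compound 1 to compound 2 (0.23 log units; within the scatter) is within the scatter. Compound 3 `COc1ncc(-c2ccc3c(c2)N(CCCn2ccccc2=O)C(=O)CO3)cc1NS(=O)(=O)c1ccc(F)cc1F` carries a group of 9 heavy atoms (7 carbon, 1 nitrogen, 1 oxygen; one six-membered aromatic ring with 1 hetero atom) in place of a group of 6 heavy atoms (5 carbon, 1 nitrogen; one six-membered aromatic ring with 1 hetero atom), on a saturated chain carbon bound to an amide-type nitrogen in a ring. Only a 1.7-fold higher number from compound 1 to compound 2 (0.23 log units; within the scatter) bears on this change, and it stayed within the scatter, so in this assay compound 3 is expected to move by a 1.2-fold lower number from compound 2 to compound 3 (0.09 log units; within the scatter), nothing beyond the scatter. Compound 3 is estimated at 4500 nM, range 1500 nM to 13000 nM.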

Compound 3, half-maximal inhibitory concentration: 12400 nM
Compound 3: middle estimate off by 2.8-fold (0.44 log units), on the low side; low and high end bracket the measured number.
By their numbers in this assay, from the lowest: compounds 1 and 2 (each within the scatter of the next); then compound 3.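

Among these compounds, this position is not indifferent to the group it carries: in this assay the group of 9 heavy atoms in place of pyridin-4-yl gives a 2.3-fold higher number from compound 2 to compound 3 (0.35 log units; beyond the scatter) and thus the first step here beyond the scatter. Against the six-membered non-aromatic ring group on the chain, the six-membered aromatic ring group gives a 3.8-fold higher number from compound 1 to compound 3 (0.58 log units; beyond the scatter) and sets compound 3 apart from the other two compounds. No measurement available here accounts for either step.

As far as these compounds go, whether an amine or a carboxylic acid on the same chain would give a lower number than compound 1 remains open. Also open, from the compounds shown here alone, is whether a longer chain ending in pyridin-4-yl would stay near compound 2 or move toward compound 3.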